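Moving a hydroxyl group: what it did to inhibition

The source may hold more compounds than are shown below. What is called first, only, known or untested is meant among the compounds shown, and "the series" means these compounds.

Compound 1, `Oc1cccc(-c2cc(-c3ccsc3)cc(-c3ccccc3O)n2)c1`: 10.2%
Compound 2, `Oc1cccc(-c2cc(-c3ccsc3)cc(-c3cccc(O)c3)n2)c1`: 59.2%
Compound 3, `Oc1ccccc1-c1cc(-c2cccnc2)cc(-c2ccccc2O)n1`: 66.4%

Three compounds were tested in an assay on isolated protein for inhibition of DNA topoisomerase 1 (Homo sapiens), with a stated time of 30 min, tested at 100 uM; a lower number here means a weaker effect, a higher number a stronger effect of the compound at the concentration tested. Compound 2 and compound 3 lie within the scatter of each other, so no order between them is claimed; compound 1 sits well below both. From compound 1 to compound 2 the change is 3-hydroxyphenyl in place of 2-hydroxyphenyl on an aromatic carbon and the step is a number 49 percentage points higher from compound 1 to compound 2 (beyond the scatter). Compound 4, `Oc1cccc(-c2cc(-c3cccnc3)cc(-c3ccccc3O)n2)c1`, is not yet measured; it arises from compound 3 by 3-hydroxyphenyl in place of 2-hydroxyphenyl on an aromatic carbon. This is the same kind of change, not the same: at the place in compound 3 the ring is meta to a 2-hydroxyphenyl group and meta to a pyridin-3-yl group, where in compound 1 it is meta to a 3-hydroxyphenyl group and meta to a thiophen-3-yl group. The difference between the cores of compound 1 and compound 3 is not broken down here. Because compound 3 already gives 66.4%, a smaller upward step than the earlier one is expected, a number 13.6 percentage points higher from compound 3 to compound 4 (beyond the scatter). Compound 4 is estimated at 80%, between 60% and 95%.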

Compound 4, a percentage reported as inhibition, at one concentration (the size of the read-out at that concentration, not a potency): 1.9%
The estimate for compound 4 lay 78.1 percentage points above the measured number, and the stated range ends above it.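

In this assay, 3-hydroxyphenyl in place of 2-hydroxyphenyl does not carry from one core to the other, and the direction of the step reverses: the same change on two cores in this assay, a number 49 percentage points higher (beyond the scatter) from compound 1 to compound 2 and a number 64.5 percentage points lower (beyond the scatter) from compound 3 to compound 4, 113.5 percentage points apart, beyond the scatter of two such steps. On the second core the change gives a number 64.5 percentage points lower from compound 3 to compound 4 (beyond the scatter), while pyridin-3-yl in place of thiophen-3-yl gives a number 8.3 percentage points lower from compound 1 to compound 4 (within the scatter). The outcome of the change thus depends on its core in these compounds, but the data do not show whether the pyridin-3-yl and thiophen-3-yl groups or the remaining hydroxyphenyl group set this difference.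

Still open, from the compounds shown here alone, is how a core carrying pyridin-3-yl with two 3-hydroxyphenyl groups would behave. Also open, going by these compounds, is what an amine or a carboxylic acid in place of the hydroxyl would give.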